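This account rests on a few compounds, and the source may have more. Where it says the series, first, only, none or still open, it means among the compounds named here.

Measured compounds:
Compound 1 `COC(=O)c1cccn1-c1ccc(Nc2ncc(Cl)c(Nc3ccccc3NS(C)(=O)=O)n2)c(OC)c1` gives 790 nM in a functional assay on KARPAS-299 cells (Homo sapiens) for antiproliferative activity, read by MTT assay, with a stated time of 4 h; a lower number here means a stronger inhibitor, a higher number a weaker inhibitor.
Compound 2 `CCN1CCN(C(=O)c2cccn2-c2ccc(Nc3ncc(Cl)c(Nc4ccccc4NS(C)(=O)=O)n3)c(OC)c2)CC1` gives 1410 nM in this assay.
Compound 3 `COc1cc(-n2cccc2C(=O)N2CCC(C)CC2)ccc1Nc1ncc(Cl)c(Nc2ccccc2NS(C)(=O)=O)n1` gives 1370 nM in this assay.

All three compounds share one core and differ only in the group on the carbonyl carbon attached to the aromatic ring. Compound 3 sits close to compound 2, with a 1.0-fold lower number from compound 2 to compound 3 (0.01 log units; within the scatter), and its distance from compound 1 is a 1.7-fold higher number from compound 1 to compound 3 (0.24 log units; within the scatter); neither step leaves the scatter, so the three numbers cannot be told apart on this evidence.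

Compound 4 `COc1cc(-n2cccc2C(=O)NCCO)ccc1Nc1ncc(Cl)c(Nc2ccccc2NS(C)(=O)=O)n1` has not been measured in this assay. It differs from compound 3 by (2-hydroxyethyl)amino in place of 4-methylpiperidin-1-yl on a carbonyl carbon. For the measured compounds named here, the steps that bear on this position are the exchanges among compounds 1, 2 and 3: a 1.8-fold higher number from compound 1 to compound 2 (0.25 log units; within the scatter), a 1.7-fold higher number from compound 1 to compound 3 (0.24 log units; within the scatter) and a 1.0-fold lower number from compound 2 to compound 3 (0.01 log units; within the scatter). Every one of them stays inside the scatter, whether the carbonyl carries a methoxy, a piperazine or a piperidine. Going by the values given here, no measured step therefore supports a shift beyond the scatter for compound 4, in either direction, and the expected step is a 1.2-fold lower number from compound 3 to compound 4 (0.10 log units; within the scatter). On that basis compound 4 is estimated at 1100 nM in this assay, with a range from 450 nM to 2700 nM.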

Compound 4, half-maximal inhibitory concentration: 45 nM
Estimate against measurement, compound 4: 24-fold (1.39 log units) above; the measured number lies below the stated range.
By their numbers in this assay, from the lowest: compound 4; then compounds 1, 3 and 2 (each within the scatter of the next).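

In this assay the group on the carbonyl carbon proves able to move the number well beyond the scatter: (2-hydroxyethyl)amino in place of 4-methylpiperidin-1-yl gives a 30-fold lower number from compound 3 to compound 4 (1.48 log units; beyond the scatter) and in place of 4-ethylpiperazin-1-yl gives a 31-fold lower number from compound 2 to compound 4 (1.50 log units; beyond the scatter) while in place of methoxy it gives an 18-fold lower number from compound 1 to compound 4 (1.24 log units; beyond the scatter) as well. Compound 4 thus stands apart from the other three compounds, which remain within the scatter of one another, and compared with 4-methylpiperidin-1-yl the entering group has no ring and brings hydrogen-bond donors, though a single compound cannot show which of these differences counts. No measurement given here accounts for the size of this step.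

Going by these compounds, it stays open whether the hydroxyl, the amide hydrogen or the chain itself carries the step, a question that an ethylamino, a 2-methoxyethylamino or a longer 3-hydroxypropylamino group on the same carbonyl carbon would separate. On these data alone, it also stays open whether a hydroxyl held on a ring, as in 4-hydroxypiperidin-1-yl, would give a similar number at this place.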